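The source may hold more compounds than are shown below. What is called first, only, known or untested is meant among the compounds shown, and "the series" means these compounds.

Working notes on the series in an assay on HEK293 cells for inhibition of kynurenine 3-monooxygenase (Homo sapiens), read by LC-MS, with a stated time of 20 h; on this read-out lower numbers stand for stronger inhibition and higher numbers for weaker inhibition.

Compound 1 `O=C(O)CCn1c(=O)oc2cc(OCc3ccccn3)c(Cl)cc21` gives 5010 nM in this assay, the highest number of the three measured compounds. Compound 2 `C[C@@H](Oc1cc2oc(=O)n(CCC(=O)O)c2cc1Cl)c1ccc(Cl)cn1` gives 100 nM, and compound 3 `C[C@@H](Oc1cc2oc(=O)n(CCC(=O)O)c2cc1Cl)c1ccc(F)cn1` gives 25.1 nM. Both lie well below compound 1, so compound 1 is the weakest of the measured set by a margin beyond the scatter.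

Among the measured compounds shown here, the one recorded step, a 4.0-fold lower number from compound 2 to compound 3 (0.60 log units; beyond the scatter), concerns a halogen swap on the pyridine ring that compounds 2 and 3 carry; it does not touch the part of the structure altered here.

Compound 4 `O=C(O)CCn1c(=O)oc2cc(Cl)c(Cl)cc21` is the next compound to be measured. The change from compound 1 is chloro in place of (pyridin-2-yl)methoxy on an aromatic carbon. For the measured compounds named here, no measured pair separates the (pyridin-2-yl)methoxy group from a bare halogen at that position, so the step has no direct precedent. What the three measured compounds show is that elaboration of that group, from compound 1 to compounds 2 and 3, lowered the number markedly; stripping it to a single chloro atom is expected to go the other way, with some loss in this assay.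

For compound 4 the expected value is 15000 nM, within 3000 nM to 60000 nM, which means an estimated step of a 3.0-fold higher number from compound 1 to compound 4 (0.48 log units; beyond the scatter).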

Compound 4, half-maximal inhibitory concentration: 2000 nM
Compound 4: middle estimate off by 7.5-fold (0.88 log units), on the high side, and the stated range ends above it.
By their numbers in this assay, from the lowest: compound 3; then compound 2; then compound 4; then compound 1.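

In this assay, the step from (pyridin-2-yl)methoxy to chloro gives a 2.5-fold lower number from compound 1 to compound 4 (0.40 log units; beyond the scatter), so at this position, on an aromatic carbon ortho to a chloro group, the single chlorine atom does better than the larger group it replaces. The aromatic ring and the two hydrogen-bond acceptors of (pyridin-2-yl)methoxy are therefore not needed on the core of compound 1 to reach the number of compound 4, and in this pair they bring no advantage over chloro. No supporting measurement bears on this step, so the reason for the direction of the change remains unexplained.

The compounds shown leave open whether the trend is specific to chloro or extends to other single-atom or compact groups at this position, such as fluoro, bromo or methoxy. They also leave open how a more distinct replacement on the same aromatic carbon, such as an amine or a longer alkyl chain, would compare with chloro and (pyridin-2-yl)methoxy.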